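Thiophene in place of hydroxyphenyl on the hydrazone carbon

The source may hold more compounds than are shown below. What is called first, only, known or untested is meant among the compounds shown, and "the series" means these compounds.

The measured compounds and their values:
compound 1, `COc1ccccc1/C=N/Nc1nc2ccccc2nc1Cc1ccccc1`, 790000 nM
compound 2, `C(=N/Nc1nc2ccccc2nc1Cc1ccccc1)\c1ccccc1`, 320000 nM
compound 3, `C/C(=N\Nc1nc2ccccc2nc1Cc1ccccc1)c1ccc(O)cc1`, 8400000 nM

All three share one core and were tested in an assay on isolated protein for inhibition of Amine oxidase [flavin-containing] B (Homo sapiens), read by spectrophotometry; a higher number here means a weaker inhibitor, a lower number a stronger inhibitor. Compound 3, with its 4-hydroxyphenyl and a methyl on the imine carbon, gives 8400000 nM and stands highest of the three numbers; compound 1 lies nearer to it and compound 2 furthest from it. For the measured compounds named here, the one single-point step among the measured compounds is a 2.5-fold lower number from compound 1 to compound 2 (0.39 log units; beyond the scatter), a modest change in the substituent on the aromatic ring.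

Compound 4, `C/C(=N\Nc1nc2ccccc2nc1Cc1ccccc1)c1cccs1`, differs from compound 3 by thiophen-2-yl in place of 4-hydroxyphenyl on a carbon with a double bond to nitrogen. Going by the values given here, no measured step covers an exchange of one aromatic ring for another, so the step from compound 1 to compound 2 bears on it only loosely, as a sign that changes on this ring move the number by modest amounts. With compound 3 sitting far above compound 1 and compound 2, the estimate for compound 4 is a lower number than compound 3, expected as a 5.6-fold lower number from compound 3 to compound 4 (0.75 log units; beyond the scatter), with wide uncertainty. Compound 4 is therefore estimated at 1500000 nM, in the range 300000 nM to 8000000 nM.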

Compound 4, half-maximal inhibitory concentration: 850000 nM
Compound 4: middle estimate off by 1.8-fold (0.25 log units), on the high side; measured number inside the range.
By their numbers in this assay, from the lowest: compound 2; then compounds 1 and 4 (each within the scatter of the next); then compound 3.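

At the carbon with a double bond to nitrogen, the aromatic group alone proves able to shift the reading in this assay: thiophen-2-yl in place of 4-hydroxyphenyl gives a 9.9-fold lower number from compound 3 to compound 4 (0.99 log units; beyond the scatter), with the methyl on that carbon and the rest of the structure unchanged. Since that methyl is present in both compounds, it does not by itself go with a number as high as that of compound 3, and the exchange of the whole group on the ring nitrogen gives a 2.7-fold higher number from compound 2 to compound 4 (0.42 log units; beyond the scatter), a step that combines the methyl with the change from phenyl to thiophen-2-yl and so cannot assign the shift to either one. Nothing measured here explains why the thiophen-2-yl compound gives the lower number.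

The compounds shown leave open whether the step tracks the loss of the hydroxyl or the change of ring, a question that an unsubstituted phenyl on the methyl-bearing carbon would address directly. They also leave open how a furan-2-yl, or a 4-aminophenyl, at this same carbon would read in this assay.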